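The compounds below may be only part of what the source reports. "The series", "measured", "known", "first", "only" and "open" are said of these compounds alone.

Measured in a functional assay on HCT-116 cells (Homo sapiens) for cytotoxicity, read by sulforhodamine B assay, with a stated time of 48 h; a higher number here means a weaker inhibitor of growth, a lower number a stronger inhibitor of growth:
- compound 1 `COc1ccc(-c2cs/c(=N\NC(=O)c3ccc(O)cc3)n2-c2ccc(OC)cc2OC)cc1`: 5130 nM
- compound 2 `O=C(c1ccc(O)cc1)n1nc(-c2c(Cl)cccc2Cl)sc1=S`: 10700 nM
- compound 3 `Cc1ccc(-c2cs/c(=N\NC(=O)c3ccc(O)cc3)n2-c2c(C)cccc2C)cc1`: 22900 nM

Compound 1 gives the lowest number of the three in this assay; compound 2 lies higher by a margin beyond the usual scatter, and compound 3 higher still, also beyond it. Among the compounds with values here, compound 2 and compound 3 each differ from compound 1 in more than one place, so no single step between measured compounds is available.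

Compound 4 `COc1ccc(-n2c(-c3ccc(Cl)cc3)cs/c2=N\NC(=O)c2ccc(O)cc2)c(OC)c1` differs from compound 1 in one place: chloro in place of methoxy on an aromatic carbon, which one bond further out reads 4-methoxyphenyl to 4-chlorophenyl. Within the data shown here, with no step of this kind measured, the expectation for this assay is a change not beyond the scatter, in no fixed direction, so the step from compound 1 to compound 4 is estimated as a 1.0-fold lower number from compound 1 to compound 4 (0.01 log units; within the scatter). Compound 4 is accordingly estimated at 5000 nM, with a range of 2000 nM to 13000 nM.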

Compound 4, concentration for 50% growth inhibition: 27500 nM
The estimate for compound 4 lay 5.5-fold (0.74 log units) below the measured number; the measured number lies above the stated range.
By their numbers in this assay, from the lowest: compound 1; then compound 2; then compounds 3 and 4 (each within the scatter of the next).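

In this assay, within the data shown here, the place para to a large group proves sensitive to substitution: the change from 4-methoxyphenyl to 4-chlorophenyl gives a 5.4-fold higher number from compound 1 to compound 4 (0.73 log units; beyond the scatter), the first single-place step. On this one pair, methoxy gives the lower number and chloro the higher. Nothing at hand explains the shift. As far as these compounds go, whether the step reflects methoxy leaving or chloro entering stays open, as does the outcome with a fluoro, an amino group or a carboxylic acid at this place.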